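This account rests on a few compounds, and the source may have more. Where it says the series, first, only, none or still open, it means among the compounds named here.

Measured so far in an ADME assay on A549 cells (Homo sapiens) for cytotoxicity, read by CellTiter-Glo; a higher number here means that more compound is tolerated, a lower number that less compound is tolerated:
compound 1 `Cc1c(Cc2ccc(OC(F)(F)F)cc2)c(=O)oc2cc(OCC(O)CN3CCC(C(N)=O)CC3)ccc12`: 68200 nM
compound 2 `COC(=O)c1ccc(Cc2c(C)c3ccc(OCC(O)CN4CCC(C(N)=O)CC4)cc3oc2=O)cc1`: > 100000 nM, a limit of this assay, not a number

In this assay compound 2 stands only at the limit (the limit of > 100000 nM in this assay, at which 1 of the 2 values shown sits). Among the measured compounds shown here, the one measured step, an at least 1.4-fold higher number from compound 1 to compound 2 (0.16 log units; that floor lies within the scatter), changes the same position and has its floor within the scatter. Compound 3 `Cc1noc(C)c1-c1ccc(Cc2c(C)c3ccc(OCC(O)CN4CCC(C(N)=O)CC4)cc3oc2=O)cc1` differs from compound 2 by 3,5-dimethyl-1,2-oxazol-4-yl in place of methoxycarbonyl on an aromatic carbon. From that single step, no shift beyond the scatter is expected; for compound 3 the estimate is 100000 nM (range 40000 nM to 250000 nM), meaning an expected step of a number no higher from compound 2 to compound 3 (the limit leaves the size open).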

Compound 3, half-maximal cytotoxic concentration: 36900 nM
Beside the measured number, compound 3's estimate is 2.7-fold (0.43 log units) above it, outside the stated range (below it).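

In this assay, the group on this aromatic carbon, para to a large group, can now be seen to move the number beyond the scatter: 3,5-dimethyl-1,2-oxazol-4-yl in place of methoxycarbonyl gives an at least 2.7-fold lower number from compound 2 to compound 3 (0.43 log units; beyond the scatter). Against trifluoromethoxy the same group gives a 1.8-fold lower number from compound 1 to compound 3 (0.27 log units; within the scatter), so these two groups are not separated. From the compounds shown here alone, the value of compound 2 is a limit, not a number, so the full size of its step stays open: the limit of > 100000 nM in this assay, at which 1 of the 3 values shown sits.

Open, going by these compounds, is where a carboxylic acid or an amine on this carbon would fall relative to these three groups.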